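Same atoms, joined differently: compound 2 to compound 4

This account rests on a few compounds, and the source may have more. Where it says the series, first, only, none or still open, it means among the compounds named here.

Measured so far in a physicochemical assay for lipophilicity, using the shake flask method, measured as octanol-water partition, at pH 7.4 (a higher number here means a more lipophilic compound, a lower number a more polar compound), are these compounds
- Compound 1 `COc1cc(F)ccc1-c1ccnc2[nH]c(C3CCN(CC(=O)N(C)C)CC3)cc12` gives 2.9
- Compound 2 `CC(C)n1nc(-c2ccnc3[nH]c(C4CCN(CC(=O)N(C)C)CC4)cc23)ccc1=O` gives 2
- Compound 3 `COc1cc(C(=O)N2CCCC2)ccc1-c1ccnc2[nH]c(C3CCOCC3)cc12` gives 3

Compound 2 stands lowest of the three in this assay with 2 and compound 1 at 2.9 and compound 3 at 3 both sit beyond the scatter above it.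

Compound 4 `CC(C)n1cc(-c2ccnc3[nH]c(C4CCN(CC(=O)N(C)C)CC4)cc23)cnc1=O` has not yet been measured. It has the same atoms as compound 2, joined differently, and the change is a group of 10 heavy atoms (7 carbon, 2 nitrogen, 1 oxygen; one six-membered aromatic ring with 2 hetero atoms) in place of a group of 10 heavy atoms (7 carbon, 2 nitrogen, 1 oxygen; one six-membered aromatic ring with 2 hetero atoms), on an aromatic carbon on an aromatic carbon opposite the ring nitrogen.

Within the data shown here, the one measured step that bears on this is a number 0.90 log units lower from compound 1 to compound 2 (beyond the scatter) and it is only an indirect guide, since it exchanged a carbon-only aromatic ring for one with 2 hetero atoms. Among the measured compounds shown here, no measured step exchanges one such hetero ring group for another. The counted features of the two groups match, so only a small downward move in this assay is expected, within the scatter. The estimated step is a number 0.20 log units lower from compound 2 to compound 4 (within the scatter) and no larger shift is expected. For compound 4 the estimate is 1.8 with an expected range from 1.3 to 2.3 on current evidence.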

Compound 4, distribution coefficient: 0.4
Compound 4: middle estimate off by 1.40 log units, on the high side; the whole stated range lies above it.
By their numbers in this assay, from the lowest: compound 4; then compound 2; then compounds 1 and 3 (each within the scatter of the next).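

In this assay the rearrangement alone gives a number 1.60 log units lower from compound 2 to compound 4 (beyond the scatter), so at this place, on an aromatic carbon opposite the ring nitrogen, the read-out depends strongly on how the atoms of the group are joined, even though the two groups have the same counted features. The earlier step from a carbon-only aromatic ring to one with 2 hetero atoms showed only a modest fall, whereas the same kind of exchange here gives a number 2.50 log units lower from compound 1 to compound 4 (beyond the scatter), so among these compounds the arrangement of the hetero ring matters and not merely its presence. Nothing available here accounts for the difference between the two arrangements.

On these data alone, it remains open whether the gap between these arrangements persists with a methyl or cyclopropyl group in place of the isopropyl group on the hetero ring. As far as these compounds go, it is equally open whether the gap holds with a carboxylic acid in place of the dimethylamide on the shared core.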